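The source may report more compounds than this note shows. Statements on the series, on what has been measured and on what is new or still open speak of the compounds shown alone.

Two compounds of the shared core carry results in a functional assay on WI-38 VA13 cells (Homo sapiens) for cytotoxicity (a lower number here means that less compound is needed, a higher number that more compound is needed for the effect), so far. Compound 1 `Cc1cc(C(=O)Nc2ccc3nc(NC(=O)C4CCCCC4)sc3c2)c(C)n1C` stops at the limit > 6.2 ug/mL in this assay, a limit and not a number (the limit of > 6.2 ug/mL in this assay, at which 1 of the 2 values shown sits). Going by the values given here, compound 2 `O=C(Nc1ccc2nc(NC(=O)C3CCC3)sc2c1)c1c(Cl)cccc1Cl` gives 0.013 ug/mL in this assay, the only number in the set, and so stands alone at the low end. Compound 3 `CC(C)COC(=O)Nc1nc2ccc(NC(=O)c3c(Cl)cccc3Cl)cc2s1` differs from compound 2 by isobutoxy in place of cyclobutyl on a carbonyl carbon. Among the compounds with values here, no measured step joins two compounds that differ in one place. The change is expected to cost a little, toward more compound needed, with an estimated 2.3-fold higher number from compound 2 to compound 3 (0.36 log units; beyond the scatter). Compound 3 is estimated at 0.03 ug/mL, between 0.008 ug/mL and 0.15 ug/mL.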

Compound 3, half-maximal effective concentration: 0.0035 ug/mL
Compound 3: middle estimate off by 8.6-fold (0.93 log units), on the high side; the measured number lies below the stated range.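

On the carbonyl carbon whose other neighbour is the amide-type nitrogen, isobutoxy is more than tolerated in this assay: replacing cyclobutyl gives a 3.7-fold lower number from compound 2 to compound 3 (0.57 log units; beyond the scatter). The four-membered ring is therefore not required at this place for a low number, and the change from (cyclobutylcarbonyl)amino to (isobutoxycarbonyl)amino carries no penalty here. Nothing measured in the series bears on the reason for the shift.

Open, going by these compounds, is how far this place tolerates other groups, such as an amine, a carboxylic acid or a longer alkoxy chain. Also open, on these data alone, is whether the step holds when the dichlorophenyl carbonyl group shared by these two compounds is replaced.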